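The source may report more compounds than this note shows. Statements on the series, on what has been measured and on what is new or still open speak of the compounds shown alone.

Measured so far:
Compound 1 `COc1ccccc1N1CCN(CCCNc2ncc(C#N)cc2C(=O)N(C)C)CC1`, which in a functional assay for antagonist activity at Alpha-1A adrenergic receptor (Oryctolagus cuniculus) (on this read-out higher numbers stand for weaker binding and lower numbers for tighter binding), gives 0.794 nM.
Compound 2 `CN(C)C(=O)c1cccnc1NCCCN1CCN(c2ccccc2OC(F)(F)F)CC1`, which in this assay gives 3.16 nM.

Of the two numbers, compound 2 stands at the higher one; the gap between compound 2 and compound 1 lies beyond the scatter of repeated measurements, so compound 1 is the tighter binder of the pair. The shared core, a dimethylamide-bearing pyridine joined through a three-carbon chain to an arylpiperazine, is the same in both; the two differ in the group on the piperazine-bound aryl ring and, for compound 1, in a nitrile on the pyridine.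

Compound 3 `CN(C)C(=O)c1cccnc1NCCCN1CCN(c2ccccc2Cc2ccccc2)CC1` has not yet been measured in this assay. It differs from compound 2 in one place: benzyl in place of trifluoromethoxy on an aromatic carbon. Among the compounds with values here, no pair of measured compounds shows this exact change, so its size cannot be read from the data. The expected step is a 1.6-fold higher number from compound 2 to compound 3 (0.20 log units; within the scatter), small and in the direction of a somewhat higher number, though a result within the scatter would not surprise. On that basis compound 3 is estimated at 5 nM, with a range from 1.5 nM to 20 nM.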

Compound 3, dissociation constant: 6.31 nM
For compound 3 the middle estimate is 1.3-fold (0.10 log units) below the measured one; the range from low to high includes it.
By their numbers in this assay, from the lowest: compound 1; then compounds 2 and 3 (each within the scatter of the next).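

In this assay, benzyl in place of trifluoromethoxy, on an aromatic carbon ortho to a large group, gives a 2.0-fold higher number from compound 2 to compound 3 (0.30 log units; within the scatter) and so leaves the two compounds indistinguishable on this read-out. The position thus accepts a group of seven heavy atoms with a six-membered aromatic ring of its own in place of one of five heavy atoms with no ring, and the hydrogen-bond acceptor counted in trifluoromethoxy can go without a shift beyond the scatter; the earlier pair differed in more than one place and could not show this for the position alone. No measurement at hand offers an explanation for this result.

As far as these compounds go, whether the position accepts other kinds of group, such as an amine, a carboxylic acid or a longer alkyl chain, remains open, as does whether a phenyl ring attached directly to the aromatic carbon would behave like benzyl. Also open, from the compounds shown here alone, is whether the same change would give a similar step on the core of compound 1, which carries a nitrile.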